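From diethylamino to ethyl(methyl)amino: what size of step?

The source may hold more compounds than are shown below. What is called first, only, known or untested is meant among the compounds shown, and "the series" means these compounds.

Measured so far in a functional assay on UMUC3 cells (Homo sapiens) for antiproliferative activity, read by MTT assay, with a stated time of 72 h; on this read-out higher numbers stand for weaker inhibition and lower numbers for stronger inhibition:
compound 1 `CC(C)NC(=N)NC(=N)Nc1ccc(C(F)(F)F)cc1` gives 5200 nM
compound 2 `CC(C)CNC(=N)NC(=N)Nc1ccc(C(F)(F)F)cc1` gives 2000 nM
compound 3 `CCN(CC)C(=N)NC(=N)Nc1ccc(C(F)(F)F)cc1` gives 4900 nM

Among these three, compound 3 stands at 4900 nM on the scale. Its closest neighbour is reached by a 1.1-fold lower number from compound 1 to compound 3 (0.03 log units; within the scatter) and its furthest by a 2.5-fold higher number from compound 2 to compound 3 (0.39 log units; beyond the scatter) in the same test.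

Compound 4 `CCN(C)C(=N)NC(=N)Nc1ccc(C(F)(F)F)cc1` shortens the diethylamino group to ethyl(methyl)amino, and hydrogen in place of methyl on a saturated chain carbon bound to an amine nitrogen is the counted change: hydrogen in place of methyl on a saturated chain carbon bound to an amine nitrogen.

Within the data shown here, no measured pair makes exactly this change, so the guides are other swaps on the same amine group. The step of a 2.6-fold lower number from compound 1 to compound 2 (0.41 log units; beyond the scatter) is only modest, and the step of a 1.1-fold lower number from compound 1 to compound 3 (0.03 log units; within the scatter) stays within the scatter. Neither points to a large move, so a small shift towards a higher number in this assay is expected, and it may not exceed the scatter.

The step expected here is a 1.2-fold higher number from compound 3 to compound 4 (0.09 log units; within the scatter) as a rough guide. For compound 4 the estimated value is 6000 nM as a central figure. The expected range for compound 4 runs from 2800 nM to 12000 nM in this test.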

Compound 4, half-maximal inhibitory concentration: 6900 nM
The estimate for compound 4 lay 1.2-fold (0.06 log units) below the measured number; the measured number falls inside the stated range.
By their numbers in this assay, from the lowest: compound 2; then compounds 3, 1 and 4 (each within the scatter of the next).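

In this assay, cutting the diethylamino group back to ethyl(methyl)amino gives a 1.4-fold higher number from compound 3 to compound 4 (0.15 log units; within the scatter) and so leaves the result inside the scatter. Among these compounds, this is the first direct look at a single methyl on this saturated chain carbon, and at this size the change has no readable effect. The same holds for a 1.3-fold higher number from compound 1 to compound 4 (0.12 log units; within the scatter), so isopropylamino, diethylamino and ethyl(methyl)amino cannot be told apart here, while a 3.5-fold higher number from compound 2 to compound 4 (0.54 log units; beyond the scatter) sets the isobutylamino group of compound 2 further from the new compound than from either earlier neighbour and leaves compound 2 as the one clear outlier, with the lowest number of the set.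

Going by these compounds, whether this lower number extends to a longer chain such as n-butyl, or to a ring amine such as pyrrolidine, remains open from these compounds. No measurement bears on what separates the isobutylamino group from the other three amine groups.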